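This account rests on a few compounds, and the source may have more. Where it says the series, first, only, none or still open, it means among the compounds named here.

Measured so far:
compound 1 `CCc1nc(-c2cccc(F)c2)c(C(=O)N2CCN(c3cccc(OC)c3)CC2)o1`, 201 nM
compound 2 `Cc1nc(-c2ccccc2F)c(C(=O)N2CCN(c3cccc(Cl)c3)CC2)o1`, 39.4 nM

In a functional assay on HL-60 cells (Homo sapiens) for inhibition, read by MTT assay, with a stated time of 72 h (a higher number here means a weaker inhibitor, a lower number a stronger inhibitor), compound 1 gives 201 nM, the higher of the two numbers; compound 2 gives 39.4 nM, and the gap to compound 1 lies beyond the scatter. Compound 2 differs from compound 1 in more than one place, so the gap is not assigned to any single change. Compound 3 `COc1cccc(N2CCN(C(=O)c3oc(C)nc3-c3cccc(F)c3)CC2)c1` is the next compound. It differs from compound 1 by hydrogen in place of methyl on a saturated chain carbon bound to an aromatic carbon. Within the data shown here, no single-change step is yet known; the change is only the loss of a methyl, so the step of a 1.1-fold lower number from compound 1 to compound 3 (0.05 log units; within the scatter) is expected to be small, in no fixed direction, and within the scatter. Compound 3 is expected at 180 nM, between 70 nM and 450 nM.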

Compound 3, half-maximal inhibitory concentration: "not active" (no number reported)
For compound 3 the study gives words and no number, and the estimate cannot be compared.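

Among these compounds, compound 3 is reported in words only, with no number, so no step from compound 1 to compound 3 can be read. The compounds shown leave open what the ethyl to methyl change does to potency. No supporting measurement bears on this result.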